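Working notes: from compound 3 to compound 4

The source may hold more compounds than are shown below. What is called first, only, known or untested is meant among the compounds shown, and "the series" means these compounds.

Measured so far:
Compound 1, `N=C(NCCCc1c[nH]cn1)NCCC(c1ccc(F)cc1)c1ccccn1`: in a functional assay on muscle tissue for agonist activity at histamine H2 receptor (Cavia porcellus) (a higher number here means a larger maximal response, a lower number a smaller maximal response), compound 1 gives 0.8.
Compound 2, `N=C(NCCCc1c[nH]cn1)NCCC(c1ccc(Br)cc1)c1ccccn1`: in this assay compound 2 gives 0.4.
Compound 3, `N=C(NCCCc1c[nH]cn1)NCCC(c1cccc(F)c1)c1ccccn1`: in this assay compound 3 gives 0.5.

Compound 3 stands second highest of the three, with a number 0.10 higher from compound 2 to compound 3 (within the scatter) and a number 0.30 lower from compound 1 to compound 3 (beyond the scatter). Compound 4, `N=C(NCCCc1c[nH]cn1)NCCC(c1cccc(C(F)(F)F)c1)c1ccccn1`, is not yet measured; it differs from compound 3 in one place: trifluoromethyl in place of fluoro on an aromatic carbon. For the measured compounds named here, the one measured step that swaps a group on the same aromatic carbon type is a number 0.40 lower from compound 1 to compound 2 (beyond the scatter), a large drop; the only other step, a number 0.30 lower from compound 1 to compound 3 (beyond the scatter), also lowered the response. Both point downward, so a modest lowering beyond the scatter is expected for compound 4, namely a number 0.20 lower from compound 3 to compound 4 (beyond the scatter). The expected value for compound 4 in this assay is 0.3, with a range from 0.1 to 0.5.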

Compound 4, intrinsic activity: the largest response reached, as a fraction of the reference agonist's: 0.7
Compound 4: middle estimate off by 0.40, on the low side; measured number above the stated range.
By their numbers in this assay, from the lowest: compounds 2 and 3 (each within the scatter of the next); then compounds 4 and 1 (each within the scatter of the next).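

In this assay, for the compounds shown here, trifluoromethyl in place of fluoro on this aromatic carbon gives a number 0.20 higher from compound 3 to compound 4 (beyond the scatter), the first upward step beyond the scatter, and the same group also gives a number 0.30 higher from compound 2 to compound 4 (beyond the scatter). The lower response of compound 3 therefore does not hold for every group at this place on the ring, with a number 0.10 lower from compound 1 to compound 4 (within the scatter). Nothing available here bears on why this change shifts the response. On these data alone, whether a chloro, a methoxy or an amine at this place would track with fluoro or with trifluoromethyl remains open.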